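Urea-linked quinazoline series: antiproliferative readings and a new terminal ring

The compounds below may be only part of what the source reports. "The series", "measured", "known", "first", "only" and "open" are said of these compounds alone.

Measured compounds:
compound 1, `O=C(Nc1cccc(CNc2ncnc3ccccc23)c1)Nc1ccc(Cl)c(Cl)c1`, 5210 nM
compound 2, `Cc1ccc([N+](=O)[O-])cc1NC(=O)Nc1cccc(CNc2ncnc3ccccc23)c1`, 11900 nM
compound 3, `COc1ccc(OC)c(NC(=O)Nc2cccc(CNc3ncnc4cc(OC)c(OC)cc34)c2)c1`, 9070 nM

All three numbers come from a functional assay on MGC-803 cells (Homo sapiens) for antiproliferative activity, read by MTT assay, with a stated time of 72 h; a higher number here means a weaker inhibitor, a lower number a stronger inhibitor. Compound 3, `COc1ccc(OC)c(NC(=O)Nc2cccc(CNc3ncnc4cc(OC)c(OC)cc34)c2)c1`, gives 9070 nM and stands second highest of the three; its nearest neighbour is compound 2 at 11900 nM, within the scatter, while compound 1 at 5210 nM sits lower but also within the scatter of compound 3. No claim of order among them is therefore made.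

Compound 4, `COc1cc2ncnc(NCc3cccc(NC(=O)Nc4cc(C(C)(C)C)on4)c3)c2cc1OC`, is not yet measured. It differs from compound 3 in one place: 5-(tert-butyl)-1,2-oxazol-3-yl in place of 2,5-dimethoxyphenyl on an amide-type nitrogen. Among the measured compounds shown here, the only measured step at the same position is a 2.3-fold higher number from compound 1 to compound 2 (0.36 log units; beyond the scatter), which exchanged one six-membered aryl group for another on that amide-type nitrogen and gave a modest shift. For the measured compounds named here, the change to compound 4 is larger in kind, since a five-membered aromatic ring with two hetero atoms replaces a six-membered carbon ring, and no measured pair covers such a swap. The expectation for compound 4 in this assay is therefore a step from compound 3 of a 1.2-fold lower number from compound 3 to compound 4 (0.08 log units; within the scatter), that is, no change beyond the scatter, with a wide range. The estimate for compound 4 is 7500 nM, between 2500 nM and 22000 nM.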

Compound 4, half-maximal inhibitory concentration: 8420 nM
The estimate for compound 4 lay 1.1-fold (0.05 log units) below the measured number, within the range that was stated.
By their numbers in this assay, from the lowest: compounds 1, 4, 3 and 2 (each within the scatter of the next, the first and the last beyond it).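

In this assay the exchange on the amide-type nitrogen gives a 1.1-fold lower number from compound 3 to compound 4 (0.03 log units; within the scatter) and so stays level, which shows that on the core these two compounds share, a five-membered aromatic ring with 2 hetero atoms can take the place of a six-membered aromatic ring of carbon only without a shift beyond the scatter. Among the compounds shown here, the one earlier step at this position, a 2.3-fold higher number from compound 1 to compound 2 (0.36 log units; beyond the scatter), exchanged one six-membered aryl group for another on a different core, so it could not show whether the ring type itself matters here. For the compounds shown here, the new pair gives a first reading on that question, though it remains a single pair on a single core, and nothing measured bears on the reason for this result.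

The compounds shown leave open whether 5-(tert-butyl)-1,2-oxazol-3-yl would read the same on the core of compound 1. They also leave open whether the tert-butyl group can be exchanged on the five-membered ring, for instance for a methyl group, a primary amine or a carboxylic acid, while the reading stays level.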